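A Triazole Aryl Swap Read Against an Assay Ceiling

The source may hold more compounds than are shown below. What is called first, only, known or untested is meant among the compounds shown, and "the series" means these compounds.

Compound 2 `N#CC1=C(N)Oc2c(N)cc3nc4ccccc4nc3c2C12C(=O)N(Cc1cnnn1-c1ccc(Cl)cc1)c1ccccc12` was examined in an ADME assay on HUVEC cells (Homo sapiens) for antiproliferative activity, read by MTT assay, with a stated time of 48 h; a higher number here means a weaker inhibitor, a lower number a stronger inhibitor. In this assay compound 2 gives only a limit of the assay, > 50000 nM, not a number. A related compound, compound 1 `N#CC1=C(N)Oc2c(c3nc4ccccc4nc3c3ccccc23)C12C(=O)N(Cc1cnnn1-c1cccc(Br)c1)c1ccccc12`, was measured alongside it. In this assay compound 1 likewise returns only a limit, > 50000 nM. Among the compounds with values here, both values thus rest at the limit of > 50000 nM in this assay, at which 2 of the 2 values shown sit, and since neither is a number, no step between compound 1 and compound 2 can be read, nor can compound 2 be placed higher or lower than compound 1.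

Compound 3 `Cc1ccc(C)c(-n2nncc2CN2C(=O)C3(C(C#N)=C(N)Oc4c(N)cc5nc6ccccc6nc5c43)c3ccccc32)c1` has not yet been tested. It differs from compound 2 in a single place: 2,5-dimethylphenyl in place of 4-chlorophenyl on an aromatic nitrogen.

The analyst expects the step from compound 2 to compound 3 in this assay to stay within the scatter, because compound 2 itself stands at > 50000 nM and nothing measured points elsewhere. He estimates compound 3 at 60000 nM in this assay, with a range from 20000 nM to 200000 nM. That estimate corresponds to an expected change of a step that the limit leaves unreadable from compound 2 to compound 3, and he anticipates that the assay will most likely again report only a limit.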

Compound 3, half-maximal inhibitory concentration: > 50000 nM
Compound 3: no number, only a limit; the forecaster's own chance of this, stated with the estimate: 80%; the middle value is on the limit's open side.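

In this assay compound 3 returns only a limit, > 50000 nM, not a number. Within the data shown here, no step from compound 2 to compound 3 can be read, because both stand at a limit: the limit of > 50000 nM in this assay, at which 3 of the 3 values shown sit. The compounds shown leave open whether exchanging 4-chlorophenyl for 2,5-dimethylphenyl changes the response, and what number any of them would give in this assay.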